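The compounds below may be only part of what the source reports. "The series", "measured", "known", "first", "only" and "open" are said of these compounds alone.

In a functional assay on HepG2 cells (Homo sapiens) for cytotoxicity, read by MTT assay, with a stated time of 72 h (on this read-out lower numbers stand for stronger inhibition and higher numbers for weaker inhibition), the measured compounds are:
compound 1 `O=C(Nc1ccc(Oc2ccnc3[nH]ccc23)cc1)c1nn(-c2ccc(Cl)cc2)ccc1=O`, 19500 nM
compound 2 `O=C(Nc1ccc(Oc2ccnc3[nH]ccc23)cc1)c1nn(-c2ccc(Br)cc2)ccc1=O`, 4280 nM
Compound 3 `Cn1ccc2c(Oc3ccc(NC(=O)c4nn(-c5ccc(Cl)cc5)ccc4=O)cc3)ccnc21` gives only a limit of the assay, > 60000 nM.

Compound 3 therefore stands beyond the numbers that were resolved, at the limit of > 60000 nM in this assay, at which 1 of the 3 values shown sits. Compound 4 `Cn1ccc2c(Oc3ccc(NC(=O)c4nn(-c5ccc(Cl)c(C(F)(F)F)c5)ccc4=O)cc3)ccnc21` differs from it by trifluoromethyl in place of hydrogen on an aromatic carbon. Neither measured step bears directly on this change: a 4.6-fold lower number from compound 1 to compound 2 (0.66 log units; beyond the scatter) concerns a halogen exchange, and an at least 3.0-fold higher number from compound 1 to compound 3 (0.48 log units; beyond the scatter) concerns the methyl on the aromatic nitrogen. With no guidance on the trifluoromethyl, and with compound 3 already at the limit, the expectation for compound 4 in this assay is a number near or beyond that limit, most likely reported again only as a limit. The expected step is a step that the limit leaves unreadable from compound 3 to compound 4. Compound 4 is estimated at 80000 nM, within 25000 nM to 250000 nM.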

Compound 4, half-maximal inhibitory concentration: 23400 nM
Compound 4: the middle estimate sits 3.4-fold (0.53 log units) above what was measured, and the stated range ends above it.
By their numbers in this assay, from the lowest: compound 2; then compounds 1 and 4 (each within the scatter of the next). At a limit, above all of these: compound 3.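

The change from 4-chlorophenyl to 4-chloro-3-(trifluoromethyl)phenyl gives an at least 2.5-fold lower number from compound 3 to compound 4 (0.40 log units; beyond the scatter) in this assay. A substituent on this aromatic carbon, ortho to a chloro group, can therefore move the number towards stronger inhibition, which the halogen exchange and the methyl on the aromatic nitrogen could not show. The full size of this step remains unknown, since compound 3 stands only at a limit: the limit of > 60000 nM in this assay, at which 1 of the 4 values shown sits.

On these data alone, whether a methoxy group or an amine on this carbon would shift the number in the same direction remains open. So does whether trifluoromethyl would have the same effect in compound 1, which keeps the hydrogen on the aromatic nitrogen.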